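From cyclohexyl to 4-bromophenyl on the amine nitrogen

A few compounds are considered here, and "the series" means these few. Any claim that something is new, unique, unknown or untested is made for them only; others in the source may bear on it.

Compound 1 `COc1cccc(NC2=CC(=O)c3nc4n(c3C2=O)[C@H]2OC[C@@H](O)[C@H]2OC4)c1`: 1780 nM
Compound 2 `O=C1C=C(NC2CCCC2)C(=O)c2c1nc1n2[C@H]2OC[C@@H](O)[C@H]2OC1`: > 8000 nM, a limit of the assay
Compound 3 `O=C1C=C(NC2CCCCC2)C(=O)c2c1nc1n2[C@H]2OC[C@@H](O)[C@H]2OC1`: > 8000 nM, a limit of the assay

In a functional assay on MGC-803 cells (Homo sapiens) for inhibition, read by sulforhodamine B assay (a lower number here means a stronger inhibitor, a higher number a weaker inhibitor), compound 3 stands only at a limit, not a number. Compound 2 likewise stands at a limit, so two of the three values shown are limits (the limit of > 8000 nM in this assay, at which 2 of the 3 values shown sit). Compound 4 `O=C1C=C(Nc2ccc(Br)cc2)C(=O)c2c1nc1n2[C@H]2OC[C@@H](O)[C@H]2OC1` differs from compound 3 in one place: 4-bromophenyl in place of cyclohexyl on an amine nitrogen. Within the data shown here, the steps that bear on this are an at least 4.4-fold higher number from compound 1 to compound 3 (0.65 log units; beyond the scatter) and an at least 4.4-fold higher number from compound 1 to compound 2 (0.65 log units; beyond the scatter), both showing an aryl group on that nitrogen giving a lower number than a cycloalkyl; a step that the two limits leave unreadable from compound 2 to compound 3 cannot be read. Compound 4 is therefore expected to move back towards compound 1, a step of an at least 3.2-fold lower number from compound 3 to compound 4 (0.50 log units; beyond the scatter), estimated at 2500 nM within 800 nM to 8000 nM.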

Compound 4, half-maximal inhibitory concentration: 1010 nM
Compound 4: middle estimate off by 2.5-fold (0.39 log units), on the high side, within the range that was stated.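

The lower number seen with compound 1 is not peculiar to 3-methoxyphenyl: a second aryl group, 4-bromophenyl, also gives a lower number than cyclohexyl (an at least 7.9-fold lower number from compound 3 to compound 4 (0.89 log units; beyond the scatter)) and cyclopentyl (an at least 7.9-fold lower number from compound 2 to compound 4 (0.89 log units; beyond the scatter)). The two aryl groups do not separate (a 1.8-fold lower number from compound 1 to compound 4 (0.25 log units; within the scatter)). Compound 2 and compound 3 each stand at a limit, not a number: the limit of > 8000 nM in this assay, at which 2 of the 4 values shown sit.

Going by these compounds, whether unsubstituted phenyl, benzyl or pyridyl on the amine nitrogen would match compound 1 and compound 4 remains open.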